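Dimethylcarbamoyl in place of carboxymethyl: expected step

The source may hold more compounds than are shown below. What is called first, only, known or untested is meant among the compounds shown, and "the series" means these compounds.

Measured so far:
compound 1 `C/C(=N\OC(=O)C(C)(C)C)c1ccc(Sc2cc(F)cc(C3CCOCC3)c2)cc1`: 40 nM
compound 2 `CC(=O)O/N=C(\C)c1ccc(Sc2cc(F)cc(C3CCOCC3)c2)cc1`: 50 nM
compound 3 `C/C(=N\OCC(=O)O)c1ccc(Sc2cc(F)cc(C3CCOCC3)c2)cc1`: 740 nM

All three share one core and differ only in the group on the oxygen. In a functional assay (blood) for inhibition, with Homo sapiens as the target (a higher number here means a weaker inhibitor, a lower number a stronger inhibitor), compound 3 stands highest of the three numbers; the steps into it were a 19-fold higher number from compound 1 to compound 3 (1.27 log units; beyond the scatter) and a 15-fold higher number from compound 2 to compound 3 (1.17 log units; beyond the scatter), both large, while a 1.3-fold higher number from compound 1 to compound 2 (0.10 log units; within the scatter) lay within the scatter. Compound 4 `C/C(=N\OC(=O)N(C)C)c1ccc(Sc2cc(F)cc(C3CCOCC3)c2)cc1` is not yet measured. Its change from compound 3 is dimethylcarbamoyl in place of carboxymethyl on an oxygen. The carboxymethyl that set compound 3 apart from compound 1 and compound 2 leaves, and a group carrying a carbonyl enters, as in those two. The two large steps into compound 3 therefore bear on this change and are expected to run back. The step expected is a 12-fold lower number from compound 3 to compound 4 (1.09 log units; beyond the scatter). Compound 4 is estimated at 60 nM, with a range of 25 nM to 200 nM.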

Compound 4, half-maximal inhibitory concentration: 2610 nM
For compound 4 the middle estimate is 44-fold (1.64 log units) below the measured one; measured number above the stated range.
By their numbers in this assay, from the lowest: compounds 1 and 2 (each within the scatter of the next); then compound 3; then compound 4.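

In this assay a carbonyl on this oxygen does not alone hold the low numbers: dimethylamino on the carbonyl carbon gives a 52-fold higher number from compound 2 to compound 4 (1.72 log units; beyond the scatter) and a 65-fold higher number from compound 1 to compound 4 (1.81 log units; beyond the scatter) in this series. Carboxymethyl also no longer marks the high end on this oxygen, as dimethylcarbamoyl gives a 3.5-fold higher number from compound 3 to compound 4 (0.55 log units; beyond the scatter) here. No evidence at hand accounts for these steps.

Open, on these data alone, is whether a methylamino group or an unsubstituted amino group on the carbonyl carbon stays as high as dimethylamino. Also open, as far as these compounds go, is where a longer carbon chain such as ethyl or propyl falls on that carbon.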